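The compounds below may be only part of what the source reports. "The series", "measured", "known", "first", "only" and "open" are said of these compounds alone.

Measured so far in a functional assay on HEK293 cells for agonist activity at D(4) dopamine receptor (Homo sapiens), read by FLIPR; a lower number here means that less compound is needed, a higher number that more compound is needed for the effect:
compound 1 `Cc1cc(NC(=O)CN2CCC(c3cccc[n+]3[O-])CC2)ccc1F`: 18 nM
compound 2 `O=C(CN1CCC(c2cccc[n+]2[O-])CC1)Nc1cc(Cl)cc(Cl)c1`: 160 nM
compound 3 `O=C(CN1CCC(c2cccc[n+]2[O-])CC1)Nc1ccc(F)cc1`: 85 nM

Compound 3 gives the second highest number of the three in this assay. Its nearest neighbour is compound 2, with a 1.9-fold lower number from compound 2 to compound 3 (0.27 log units; within the scatter); the furthest is compound 1, with a 4.7-fold higher number from compound 1 to compound 3 (0.67 log units; beyond the scatter).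

Compound 4 `Cc1ccc(Cl)cc1NC(=O)CN1CCC(c2cccc[n+]2[O-])CC1` differs from compound 3 by 5-chloro-2-methylphenyl in place of 4-fluorophenyl on an amide-type nitrogen. Among the compounds with values here, two measured steps bear on this change. The step of a 4.7-fold higher number from compound 1 to compound 3 (0.67 log units; beyond the scatter) shows that loss of the methyl on the aromatic ring raised the number beyond the scatter, and compound 4 carries a methyl again as part of the 5-chloro-2-methylphenyl group. The step of a 1.9-fold lower number from compound 2 to compound 3 (0.27 log units; within the scatter) shows that exchanging halogen pattern alone, dichlorophenyl against fluorophenyl, stayed within the scatter. The step of an 8.9-fold higher number from compound 1 to compound 2 (0.95 log units; beyond the scatter) combined both changes and gave the largest rise. The methyl is therefore expected to matter most, and the number for compound 4 is expected to come down beyond the scatter relative to compound 3, a 2.8-fold lower number from compound 3 to compound 4 (0.45 log units; beyond the scatter). The estimate for compound 4 in this assay is 30 nM, with a range from 10 nM to 100 nM.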

Compound 4, half-maximal effective concentration: 126 nM
Compound 4: the middle estimate sits 4.2-fold (0.62 log units) below what was measured, outside the stated range (above it).
By their numbers in this assay, from the lowest: compound 1; then compounds 3, 4 and 2 (each within the scatter of the next).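

In this assay, a methyl on the aromatic ring does not by itself bring the number down: compound 4, with 5-chloro-2-methylphenyl, cannot be separated from its 4-fluorophenyl counterpart (a 1.5-fold higher number from compound 3 to compound 4 (0.17 log units; within the scatter)) or its 3,5-dichlorophenyl counterpart (a 1.3-fold lower number from compound 2 to compound 4 (0.10 log units; within the scatter)). Only the 4-fluoro-3-methylphenyl group of compound 1 stands apart (a 7.0-fold higher number from compound 1 to compound 4 (0.85 log units; beyond the scatter)), so the link between methyl and a lower number holds for that group alone, and compound 4 goes against it. Nothing available gives a reason for this difference between the two methyl-bearing groups.

Compound 4 changes methyl and halogen together, so the part played by each on this ring stays unresolved. From the compounds shown here alone, whether a methoxy or an amine on the phenyl ring would reach the level of compound 1 also remains open.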